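From 4-bromo-3-nitrophenyl to 4-methyl-3-nitropiperazin-1-yl

This account rests on a few compounds, and the source may have more. Where it says the series, first, only, none or still open, it means among the compounds named here.

Compound 1 `O=C(O)c1ccc(C(=O)/C(=C\c2ccc(Br)c([N+](=O)[O-])c2)SCc2ccc(Br)cc2)cc1` carries a 4-bromo-3-nitrophenyl group on a double-bonded chain carbon bound to a double-bonded chain carbon, and a 4-bromophenyl group on a saturated chain carbon bound to a sulfur. In a functional assay on DU-145 cells (Homo sapiens) for inhibition, read by trypan blue exclusion, with a stated time of 96 h (a lower number here means a stronger inhibitor of growth, a higher number a weaker inhibitor of growth), compound 1 gives 1000 nM. Compound 2 `O=C(O)c1ccc(C(=O)/C(=C\c2ccc(Br)c([N+](=O)[O-])c2)SCc2ccccc2Cl)cc1` gives 1000 nM, so the step of no change at the digits printed from compound 1 to compound 2 (within the scatter). For compound 3 `O=C(O)c1ccc(C(=O)/C(=C\c2ccc(Br)c([N+](=O)[O-])c2)SCc2ccc(Cl)cc2)cc1` the assay reports only a limit, < 1000 nM. Accordingly the step of a number no higher from compound 1 to compound 3 (the limit leaves the size open), and likewise a number no higher from compound 2 to compound 3 (the limit leaves the size open). Compound 1 thus stands level with compound 2, while compound 3 sits at the limit (the limit of < 1000 nM in this assay, at which 1 of the 3 values shown sits).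

Compound 4 `CN1CCN(/C=C(/SCc2ccc(Br)cc2)C(=O)c2ccc(C(=O)O)cc2)CC1[N+](=O)[O-]` has not been measured. It differs from compound 1 in one place: 4-methyl-3-nitropiperazin-1-yl in place of 4-bromo-3-nitrophenyl on a double-bonded chain carbon bound to a double-bonded chain carbon. Among the measured compounds shown here, none of the measured steps alters this part of the shared core; they exchange the group on the saturated chain carbon bound to a sulfur or swap chloro for bromo, and they show either no change or an open-ended limit. There is therefore no measured guide to the direction or size of this step, and the expectation stays near where compound 1 stands. Compound 4 is expected to give 1000 nM, within 300 nM to 5000 nM. That estimate means an expected step of no change at the digits printed from compound 1 to compound 4 (within the scatter).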

Compound 4, concentration for 50% growth inhibition: 10000 nM
Beside the measured number, compound 4's estimate is 10-fold (1.00 log units) below it, and the stated range ends below it.
By their numbers in this assay, from the lowest: compounds 1 and 2 (each within the scatter of the next); then compound 4.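

In this assay, this is the first change shown at the place on a double-bonded chain carbon bound to a double-bonded chain carbon, and unlike the earlier steps on the other side of the molecule it has a clear, readable size: a 10-fold higher number from compound 1 to compound 4 (1.00 log units; beyond the scatter). So this place does respond to a change of group, and here the exchange of 4-bromo-3-nitrophenyl for 4-methyl-3-nitropiperazin-1-yl gives a weaker inhibitor of growth. The exchange removes the aromatic ring and the bromine and brings in ring nitrogens all at once, and nothing shown here tells which of these matters.

The compounds shown leave open whether a plain phenyl ring or a morpholine ring at this place would stay level with compound 1 or fall away as compound 4 does. They also leave open whether a piperazine ring without the nitro group would behave as compound 4 does.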